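From Methoxy to Dimethylamino: An Expected Small Step

The source may report more compounds than this note shows. Statements on the series, on what has been measured and on what is new or still open speak of the compounds shown alone.

Compound 1 `COc1ccc(C2CC(c3ccccc3)=NN2C2=NC(=O)/C(=C3\C(=O)Nc4ccccc43)S2)cc1` was tested in a functional assay on cells (Leukemia cell, Homo sapiens) for cytotoxicity, read by sulforhodamine B assay, with a stated time of 48 h (on this read-out higher numbers stand for weaker inhibition of growth and lower numbers for stronger inhibition of growth), where compound 1 gives 20800 nM. Compound 2 `COc1ccc(C2=NN(C3=NC(=O)/C(=C4\C(=O)Nc5ccccc54)S3)C(c3ccc(OC)cc3)C2)cc1` carries an added methoxy on an aromatic carbon; in this assay compound 2 gives 100000 nM. For the measured compounds named here, the single measured step, a 4.8-fold higher number from compound 1 to compound 2 (0.68 log units; beyond the scatter), leaves compound 1 with the lower of the two numbers. Compound 3 `CN(C)c1ccc(C2CC(c3ccccc3)=NN2C2=NC(=O)/C(=C3\C(=O)Nc4ccccc43)S2)cc1` differs from compound 1 by dimethylamino in place of methoxy on an aromatic carbon. Going by the values given here, no measured step involves this exchange; the one known step concerns adding a group at another place, not replacing one group by another, so it gives no direct guide. The expected step is a 1.4-fold lower number from compound 1 to compound 3 (0.14 log units; within the scatter), meaning a number in the same region as compound 1 and no change beyond the scatter. Compound 3 is therefore expected to give about 15000 nM in this assay, with a range from 4000 nM to 60000 nM.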

Compound 3, concentration for total growth inhibition: 45600 nM
Beside the measured number, compound 3's estimate is 3.0-fold (0.48 log units) below it, and the stated range covers the measured number.
By their numbers in this assay, from the lowest: compound 1; then compound 3; then compound 2.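

In this assay, replacing the 4-methoxyphenyl group with 4-(dimethylamino)phenyl gives a 2.2-fold higher number from compound 1 to compound 3 (0.34 log units; beyond the scatter), so growth inhibition becomes weaker. The earlier step showed only what an added methoxy does at another place, whereas this one shows that the group on this aromatic carbon can itself shift the read-out, though only modestly, when one group of similar size replaces another. Nothing available here explains this shift.

The compounds shown leave open whether any group at this place would give a lower number than compound 1, such as a hydroxyl, a primary amine or a carboxylic acid. They also leave open whether a longer chain on the oxygen of the methoxy would move the number further in either direction.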